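Replacing the ethyl group of compound 2

The source may report more compounds than this note shows. Statements on the series, on what has been measured and on what is new or still open speak of the compounds shown alone.

In a functional assay on KB cells (Homo sapiens) for cytotoxicity, read by MTT assay, with a stated time of 72 h (a lower number here means that less compound is needed, a higher number that more compound is needed for the effect), compound 1 (`CCOc1c(-c2occ(C)c2C(=O)O)ccc2c(CC)cccc12`) gives > 10 ug/mL as a limit of the assay and not a number. Going by the values given here, compound 2 (`CCOC(=O)c1c(C)coc1-c1ccc2c(CC)cccc2c1OC`) gives 2.2 ug/mL here, the only true number so far, so there is no second number to rank it against.

Compound 3 (`CCc1cccc2c(OC)c(-c3occ(C)c3C(=O)On3nnc4ccccc43)ccc12`) has not yet been measured. Compared with compound 2, the change lies in one place, on an oxygen next to a carbonyl group: a group of 9 heavy atoms (6 carbon, 3 nitrogen; one five-membered aromatic ring with 3 hetero atoms, one six-membered aromatic ring of carbon only) in place of a group of 2 heavy atoms (2 carbon; no ring), on an oxygen next to a carbonyl group is the whole of it. The ethyl leaves, and a group with one five-membered aromatic ring with 3 hetero atoms and one six-membered aromatic ring of carbon only enters.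

Among the compounds with values here, no measured step covers such a change, so the expectation rests on compound 2 at 2.2 ug/mL alone. In this assay no step beyond the scatter is expected, and the direction is uncertain, with slightly more room towards more compound being needed. The estimated step of a 1.4-fold higher number from compound 2 to compound 3 (0.13 log units; within the scatter) is therefore small. For compound 3 the expected value is 3 ug/mL (estimated range 0.8 ug/mL to 9 ug/mL).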

Compound 3, concentration for half-maximal effect: > 10 ug/mL
Compound 3 gave a limit, no number; the forecaster's own chance of this, stated with the estimate: 15%; middle value at least 3.3-fold (0.52 log units) from the limit.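

Going by these compounds alone, this is the first readable step at this position. In this assay, exchanging the ethyl on an oxygen next to a carbonyl group for the group with one five-membered aromatic ring with 3 hetero atoms and one six-membered aromatic ring of carbon only gives an at least 4.5-fold higher number from compound 2 to compound 3 (0.65 log units; beyond the scatter), so the position is not indifferent to this exchange, and the true number of compound 2 is not kept. The step has only a lower bound, and how far compound 3 really lies from compound 2 cannot be told: the limit of > 10 ug/mL in this assay, at which 2 of the 3 values shown sit.

With a single exchange shown at this oxygen, it stays open whether the shift belongs to the size of the entering group, to its ring nitrogens or to the two rings together. A methyl or a longer chain such as butyl on the same oxygen, a benzyl group carrying a ring of carbon only, or an amide formed with a simple amine at the same carbonyl would each separate these readings and show how much change this place accepts.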